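Amine ring closure on two cores: solubility working notes

A few compounds are considered here, and "the series" means these few. Any claim that something is new, unique, unknown or untested is made for them only; others in the source may bear on it.

Measured so far in a physicochemical assay for solubility, in the presence of a further agent that is not named here; on this read-out lower numbers stand for lower solubility and higher numbers for higher solubility:
compound 1 `CCN(CC)CCNc1n[n+]([O-])c2ccc(Cl)cc2[n+]1[O-]` gives 23000000 nM
compound 2 `[O-][n+]1nc(NCCN2CCCCC2)[n+]([O-])c2cc(Cl)ccc21` gives 3200000 nM
compound 3 `CCN(CC)CCNc1n[n+]([O-])c2ccc(C(C)(C)C)cc2[n+]1[O-]` gives > 48000000 nM

The value of compound 3 in this assay is a limit of the assay, not a number, sitting at the limit of > 48000000 nM in this assay, at which 1 of the 3 values shown sits.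

Compound 4 `CC(C)(C)c1ccc2c(c1)[n+]([O-])c(NCCN1CCCCC1)n[n+]2[O-]` is not yet measured in this assay. It differs from compound 3 by piperidin-1-yl in place of diethylamino on a saturated chain carbon, two bonds along the chain from a nitrogen on an aromatic ring. The same change, from compound 1 to compound 2, is piperidin-1-yl in place of diethylamino on a saturated chain carbon, two bonds along the chain from a nitrogen on an aromatic ring, and in this assay it made a 7.2-fold lower number from compound 1 to compound 2 (0.86 log units; beyond the scatter). The two cores differ by tert-butyl in place of chloro on an aromatic carbon, which in this assay made an at least 2.0-fold higher number from compound 1 to compound 3 (0.31 log units; beyond the scatter).

If the amine change carries over, compound 4 is expected to sit lower than compound 3 in this assay by about an at least 5.3-fold lower number from compound 3 to compound 4 (0.72 log units; beyond the scatter), the scale resting on the step measured from compound 1 to compound 2, a 7.2-fold lower number from compound 1 to compound 2 (0.86 log units; beyond the scatter), but the starting point for compound 3 is only a limit, so the spread is wide. Compound 4 is estimated in this assay at 9000000 nM, between 3000000 nM and 48000000 nM.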

Compound 4, solubility: 28000000 nM
Compound 4: middle estimate off by 3.1-fold (0.49 log units), on the low side; low and high end bracket the measured number.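

In this assay, piperidin-1-yl in place of diethylamino gives an at least 1.7-fold lower number from compound 3 to compound 4 (0.23 log units; that floor lies within the scatter), against a 7.2-fold lower number from compound 1 to compound 2 (0.86 log units; beyond the scatter) on the core of compound 1, so the measured floor fits a carry-over in direction but does not establish one. Compound 3 stands at a limit of the assay, not a number: the limit of > 48000000 nM in this assay, at which 1 of the 4 values shown sits. Going by these compounds, the true size of the amine change on the core of compound 3 therefore remains unknown and cannot be matched to the step on the core of compound 1, while tert-butyl in place of chloro gives an 8.8-fold higher number from compound 2 to compound 4 (0.94 log units; beyond the scatter) with the piperidin-1-yl chain held.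

Open, on these data alone, is whether the change extends to morpholin-4-yl or pyrrolidin-1-yl. Also open, as far as these compounds go, is whether it holds on a core bearing methoxy.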